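Trifluoromethyl aryl on the cinnamamide tail of compound 2

The compounds below may be only part of what the source reports. "The series", "measured", "known", "first", "only" and "open" are said of these compounds alone.

Among the compounds with values here, compound 2 `COc1cc(NC(C)CCCNC(=O)/C=C/c2ccccc2F)c2ncccc2c1` stands as the only compound in an ADME assay on L6 cells (Rattus norvegicus) for cytotoxicity, read by resazurin assay, with a stated time of 70 h (on this read-out higher numbers stand for weaker inhibition and lower numbers for stronger inhibition), with a number rather than a limit: in this assay compound 2 gives 1.5 ug/mL. Compound 1 `COc1cc(NC(C)CCCNC(=O)/C=C/c2ccc(OC)c(OC)c2)c2ncccc2c1` differs only in its aryl group, and in this assay compound 1 reaches a limit, > 100 ug/mL, which is the limit of > 100 ug/mL in this assay, at which 1 of the 2 values shown sits. Within the data shown here, the one measured step that touches this position, an at least 66-fold lower number from compound 1 to compound 2 (1.82 log units; beyond the scatter), shows that the aryl substituent on the unsaturated chain can move the number greatly. Compound 3 `COc1cc(NC(C)CCCNC(=O)/C=C/c2cccc(C(F)(F)F)c2)c2ncccc2c1` carries the change (3-(trifluoromethyl)phenyl in place of 2-fluorophenyl on a double-bonded chain carbon bound to a double-bonded chain carbon). Among the measured compounds shown here, no measured step pairs these two aryl groups directly, so only the size of the effect seen for compound 1 against compound 2 informs the expectation. Compound 3 is expected to stay close to compound 2, with a step of a 2.0-fold higher number from compound 2 to compound 3 (0.30 log units; within the scatter) that may lie within the scatter. Compound 3 is therefore estimated at 3 ug/mL, in the range 0.6 ug/mL to 25 ug/mL.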

Compound 3, half-maximal inhibitory concentration: 7.4 ug/mL
Compound 3: the middle estimate sits 2.5-fold (0.39 log units) below what was measured; the range from low to high includes it.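

Exchanging 2-fluorophenyl for 3-(trifluoromethyl)phenyl gives, in this assay, a 4.9-fold higher number from compound 2 to compound 3 (0.69 log units; beyond the scatter), so this position responds not only to the loss of 3,4-dimethoxyphenyl but also to a change between two aryl groups that both carry fluorine. The 3-(trifluoromethyl)phenyl group still stands far from 3,4-dimethoxyphenyl, with an at least 13-fold lower number from compound 1 to compound 3 (1.13 log units; beyond the scatter). That step has a limit at one end, and compound 1 remains the only compound held at a limit: the limit of > 100 ug/mL in this assay, at which 1 of the 3 values shown sits.

The compounds shown leave open whether the step from 2-fluorophenyl belongs to the trifluoromethyl group or to its place on the ring, a question that a 3-fluorophenyl or a plain phenyl would help to settle. They also leave open how a nitrile or an amine on that ring would read in this assay.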